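Shortening the ether chain on a shared chromanone core

The source may hold more compounds than are shown below. What is called first, only, known or untested is meant among the compounds shown, and "the series" means these compounds.

Measured so far:
- compound 1, `O=C1CC(c2ccccc2OCc2ccc(F)cc2)Oc2ccccc21`, gives 45.2% in a functional assay on RAW264.7 cells (Mus musculus) for inhibition, read by immunoassay, with a stated time of 12 h, tested at 30 uM; on this read-out higher numbers stand for more inhibition at the one concentration tested (going by the name of the read-out) and lower numbers for less inhibition
- compound 2, `CC(C)CCOc1ccccc1C1CC(=O)c2ccccc2O1`, gives 47.6% in this assay

Two compounds share the same core and differ only in the group hanging from the oxygen on the aromatic ring. Within the data shown here, the one step between them, a number 2.4 percentage points higher from compound 1 to compound 2 (within the scatter), says that swapping a ring-bearing group for a branched saturated chain changed little. On the numbers shown, compound 2 therefore stands alongside compound 1, the two within the scatter of each other, so neither can be called stronger or weaker.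

Compound 3, `CCCOc1ccccc1C1CC(=O)c2ccccc2O1`, is not yet measured. It follows from compound 2 by methyl in place of isopropyl on a saturated chain carbon, two bonds along the chain from an oxygen on an aromatic ring. Among the measured compounds shown here, the only measured step, a number 2.4 percentage points higher from compound 1 to compound 2 (within the scatter), concerns a much larger exchange at the same chain and still stayed within the scatter, so it bears on this smaller trimming only loosely. No step beyond the scatter is expected in this assay; the estimated step is a number 2.6 percentage points lower from compound 2 to compound 3 (within the scatter). Compound 3 is expected to give about 45%, with a range from 30% to 60%.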

Compound 3, a percentage reported as inhibition, at one concentration (the size of the read-out at that concentration, not a potency): 45.7%
Estimate against measurement, compound 3: 0.7 percentage points below, within the range that was stated.
By their numbers in this assay, from the lowest: compounds 1, 3 and 2 (each within the scatter of the next).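

In this assay, trimming isopentyloxy to propoxy gives a number 1.9 percentage points lower from compound 2 to compound 3 (within the scatter), so at this position the far end of the saturated chain can be shortened without the read-out moving beyond the scatter. Exchanging 4-fluorophenyl for ethyl on the chain carbon bound to an oxygen on an aromatic ring gives a number 0.5 percentage points higher from compound 1 to compound 3 (within the scatter), which shows that a short, ring-free chain cannot be told apart from the ring-bearing group either, so all three groups on this oxygen now read alike within the scatter. Nothing available explains why these groups read alike.

The compounds shown leave open whether any group on this oxygen can move the number beyond the scatter, for example a methyl placed directly on the oxygen, a much longer chain, or a chain ending in an amine or a carboxylic acid. Each number also comes from a single concentration, so it gives the size of the effect at that concentration only and does not show how these compounds would compare at any other.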